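Amino in Place of Hydrogen: Where Compound 4 Should Land

A few compounds are considered here, and "the series" means these few. Any claim that something is new, unique, unknown or untested is made for them only; others in the source may bear on it.

Measured so far in a functional assay on IGROV-1 cells (Homo sapiens) for cytotoxicity, read by sulforhodamine B assay, with a stated time of 48 h; a lower number here means that less compound is tolerated, a higher number that more compound is tolerated:
compound 1 `ClCc1cccc(Cn2cnc3c(Cl)ncnc32)c1` gives > 100000 nM, which is a limit of the assay and not a number.
compound 2 `ClCc1ccc(Cn2cnc3c(Cl)nc(Cl)nc32)cc1` gives 60300 nM.
compound 3 `ClCc1cccc(Cn2cnc3nc(Cl)nc(Cl)c32)c1` gives 55000 nM.

Compound 1 stands at the top of the numbers shown: its value is only a limit, so that what is known of it is the limit of > 100000 nM in this assay, at which 1 of the 3 values shown sits. Compounds 2 and 3 give values that lie within the usual scatter of each other. No two of these compounds differ in only one place, so no measured step is available.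

Compound 4 `Nc1nc(Cl)c2ncn(Cc3cccc(CCl)c3)c2n1` arises from compound 1 by amino in place of hydrogen on an aromatic carbon, between two ring nitrogen atoms. Among the compounds with values here, with no measured step of this kind, the change expected in this assay is modest and of undetermined direction, quite possibly none beyond the scatter. Compound 4 is therefore estimated at 90000 nM, with a range from 25000 nM to 300000 nM. The step this estimate implies is an at least 1.1-fold lower number from compound 1 to compound 4 (0.04 log units; that floor lies within the scatter), and a reported limit rather than a number remains a real possibility.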

Compound 4, concentration lethal to 50% of the cells: 55000 nM
The estimate for compound 4 lay 1.6-fold (0.21 log units) above the measured number; low and high end bracket the measured number.
By their numbers in this assay, from the lowest: compounds 3, 4 and 2 (each within the scatter of the next). At a limit, above all of these: compound 1.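

At this position, on an aromatic carbon between two ring nitrogen atoms, amino in place of hydrogen gives an at least 1.8-fold lower number from compound 1 to compound 4 (0.25 log units; that floor lies within the scatter) in this assay, the first reading of this change among the compounds shown. That reading is only a floor, and since the floor lies within the scatter, it does not by itself establish a real shift. The full size of the step cannot be read, because compound 1 is known only as a limit: the limit of > 100000 nM in this assay, at which 1 of the 4 values shown sits.

Only hydrogen and amino are shown at this position, so how a methylamino group, a hydroxyl group or a longer amine chain would read here remains open. Also open, on these data alone, is what amino in place of hydrogen would do to a compound that starts from a number and not from a limit.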